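Methoxy in Place of Bromo: Estimating Compound 4

The source may hold more compounds than are shown below. What is called first, only, known or untested is meant among the compounds shown, and "the series" means these compounds.

Measured in a functional assay on PC-9 cells (Homo sapiens) for inhibition, read by MTT assay, with a stated time of 48 h, tested at 10 uM; a higher number here means more inhibition at the concentration tested (going by the name of the read-out), a lower number less inhibition:
compound 1, `COc1ccc(Br)cc1Nc1cc(NC(=O)Nc2c(Cl)cccc2Cl)ncn1`, gives 69%
compound 2, `COc1cc(NC(=O)Nc2cc(Nc3cc(Br)ccc3OC)ncn2)cc(OC)c1`, gives 82.5%
compound 3, `CCc1ccc(Nc2cc(NC(=O)Nc3c(Cl)cccc3Cl)ncn2)cc1`, gives 70.1%

Compound 1 stands lowest of these three numbers. Its nearest neighbour is compound 3, a number 1.1 percentage points higher from compound 1 to compound 3 (within the scatter), and its furthest is compound 2, a number 13.5 percentage points higher from compound 1 to compound 2 (beyond the scatter).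

Compound 4, `COc1ccc(OC)c(Nc2cc(NC(=O)Nc3c(Cl)cccc3Cl)ncn2)c1`, has not yet been tested in this assay. It differs from compound 1 in one place: methoxy in place of bromo on an aromatic carbon.

Of the two measured steps, the more telling one also alters the group on a nitrogen on an aromatic ring, and it stayed within the scatter: a number 1.1 percentage points higher from compound 1 to compound 3 (within the scatter). The other step alters the group on an amide-type nitrogen at the far end of the shared core and was modest, a number 13.5 percentage points higher from compound 1 to compound 2 (beyond the scatter); it says little about a change on this ring. Within the data shown here, with only one relevant comparison, and that one flat, no movement beyond the scatter is expected for compound 4.

Compound 4 is therefore expected to show a number 1 percentage points higher from compound 1 to compound 4 (within the scatter) in this assay. The value of compound 4 is estimated at 70%, in a range from 55% to 85%.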

Compound 4, a percentage reported as inhibition, at one concentration (the size of the read-out at that concentration, not a potency): 95%
Compound 4: middle estimate off by 25 percentage points, on the low side; measured number outside the range, above it.
By their numbers in this assay, from the lowest: compounds 1 and 3 (each within the scatter of the next); then compound 2; then compound 4.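

In this assay, the carbon that carries bromo in compound 1 proves to be a place where a single small exchange counts: methoxy in place of bromo gives a number 26 percentage points higher from compound 1 to compound 4 (beyond the scatter). The earlier step on this side of the shared core, a number 1.1 percentage points higher from compound 1 to compound 3 (within the scatter), replaced the whole substituted ring on the nitrogen and showed no movement, so it gave no sign that this side could shift the number at all; the new step shows that it can, through a change of one group on a carbon meta to a large group and para to a methoxy group. The exchange removes a bromine and brings in a carbon, an oxygen and a hydrogen-bond acceptor, but nothing available gives a reason for the step.

On these data alone, it remains open whether the rise belongs to methoxy itself or would also appear with another group on this carbon, such as an amine, a hydroxyl or an ethoxy group. Also open, as far as these compounds go, is whether methoxy here and the 3,5-dimethoxyphenyl group of compound 2 would add up in one molecule.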